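A few compounds are considered here, and "the series" means these few. Any claim that something is new, unique, unknown or untested is made for them only; others in the source may bear on it.

Of the compounds shown here, three from this series have been tested in a functional assay on CCRF-CEM cells (Homo sapiens) for antiproliferative activity, with a stated time of 72 h; a higher number here means a weaker inhibitor, a lower number a stronger inhibitor. Compound 1, with the structure `CSc1cnc2ccccc2c1[Se]CC#CCOC(=O)c1ccc(C(=O)O)cc1`, gives 4 ug/mL in this assay, the lowest of the three numbers and so the strongest inhibitor among them. Compound 2, `CSc1cnc2ccccc2c1SCC#CCOC(=O)/C=C/c1ccccc1`, gives 18.1 ug/mL, and compound 3, `O=C(/C=C/c1ccccc1)OCC#CCSc1cnc2ccccc2c1Cl`, gives 15.4 ug/mL; both gaps from compound 1 lie beyond the usual scatter of repeated measurements, compound 3 standing nearer to compound 1 and compound 2 furthest from it. Compound 4, `CSc1cnc2ccccc2c1[Se]CC#CCOC(=O)/C=C/c1ccccc1`, has not yet been measured. It differs from compound 1 in one place: 2-phenylethenyl in place of 4-carboxyphenyl on a carbonyl carbon. For the measured compounds named here, no pair of measured compounds shows exactly this change, so the size of the step is not known from direct comparison; compounds 2 and 3, which also carry the 2-phenylethenyl ester but differ from compound 4 elsewhere in the shared core, both show higher numbers than compound 1, which points towards a somewhat weaker inhibitor. The step from compound 1 to compound 4 is expected to be a 2.5-fold higher number from compound 1 to compound 4 (0.40 log units; beyond the scatter), towards a higher number. Compound 4 is therefore estimated at 10 ug/mL, within a range from 4 ug/mL to 25 ug/mL.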

Compound 4, concentration for 50% inhibition: 17.8 ug/mL
For compound 4 the middle estimate is 1.8-fold (0.25 log units) below the measured one, within the range that was stated.
By their numbers in this assay, from the lowest: compound 1; then compounds 3, 4 and 2 (each within the scatter of the next).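

In this assay, for the compounds shown here, replacing 4-carboxyphenyl with 2-phenylethenyl on the carbonyl carbon gives the only direct reading of this change: a 4.5-fold higher number from compound 1 to compound 4 (0.65 log units; beyond the scatter), so the new compound is a weaker inhibitor by more than the scatter. The group that leaves carries a hydrogen-bond donor and a hydrogen-bond acceptor and the group that enters carries neither, while both keep one six-membered aromatic ring of carbon only. Nothing measured here bears on the cause of this step.

With only these two groups compared at this position, the step cannot be pinned on the carboxylic acid or on the rest of the group. A plain phenyl, a methyl ester of the acid or an amine on the ring would help separate these possibilities.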